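Chloro to Trifluoromethyl: a Second Pair Awaits Measurement

The source may hold more compounds than are shown below. What is called first, only, known or untested is meant among the compounds shown, and "the series" means these compounds.

Compound 1 `CC(Oc1ccc(Oc2ccc(Cl)cc2)cc1)C(=O)Cn1nnc(-c2ccccc2)n1` and compound 3 `CC(Oc1ccc(Oc2ccc(Cl)cc2)cc1)C(=O)Cn1nnc(-c2ccc(Cl)cc2)n1` share a core, and the two cores differ as chloro in place of hydrogen on an aromatic carbon. In an assay on microsomes from brain for inhibition of Fatty-acid amide hydrolase 1 (Rattus norvegicus), read by fluorescence and HPLC, with a stated time of 60 min (on this read-out lower numbers stand for stronger inhibition and higher numbers for weaker inhibition), compound 1 gives 51 nM, while compound 3 gives 76 nM, so that a 1.5-fold higher number from compound 1 to compound 3 (0.17 log units; within the scatter). Compound 2 `CC(Oc1ccc(Oc2ccc(C(F)(F)F)cc2)cc1)C(=O)Cn1nnc(-c2ccccc2)n1` carries the change trifluoromethyl in place of chloro on an aromatic carbon relative to compound 1; in this assay compound 2 gives 160 nM, and a 3.1-fold higher number from compound 1 to compound 2 (0.50 log units; beyond the scatter). Compound 4 `CC(Oc1ccc(Oc2ccc(C(F)(F)F)cc2)cc1)C(=O)Cn1nnc(-c2ccc(Cl)cc2)n1` is the unmeasured partner of compound 3, carrying the change (trifluoromethyl in place of chloro on an aromatic carbon), so this same change occurs twice in the set. Going by the values given here, compound 4 is expected to show a step of about a 3.0-fold higher number from compound 3 to compound 4 (0.48 log units; beyond the scatter) in this assay, because a 3.1-fold higher number from compound 1 to compound 2 (0.50 log units; beyond the scatter) is the single precedent on which this expectation rests. Compound 4 is therefore estimated at 230 nM, with an expected range from 100 nM to 520 nM.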

Compound 4, half-maximal inhibitory concentration: 300 nM
For compound 4 the middle estimate is 1.3-fold (0.12 log units) below the measured one, within the range that was stated.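

In this assay, trifluoromethyl in place of chloro gives a 3.9-fold higher number from compound 3 to compound 4 (0.60 log units; beyond the scatter) on the core bearing the second chloro, and this agrees with the step on the core without it: the same change on two cores in this assay, a 3.1-fold higher number (0.50 log units; beyond the scatter) from compound 1 to compound 2 and a 3.9-fold higher number (0.60 log units; beyond the scatter) from compound 3 to compound 4, 1.3-fold (0.10 log units) apart, within the scatter of two such steps. Chloro in place of hydrogen gives a 1.9-fold higher number from compound 2 to compound 4 (0.27 log units; within the scatter) on the trifluoromethyl core, and this also agrees with its earlier counterpart: the same change on two cores in this assay, a 1.5-fold higher number (0.17 log units; within the scatter) from compound 1 to compound 3 and a 1.9-fold higher number (0.27 log units; within the scatter) from compound 2 to compound 4, 1.3-fold (0.10 log units) apart, within the scatter of two such steps. Each change therefore carried across this one pair of cores in this one assay, but that does not show that either would carry to a core further removed.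

As far as these compounds go, whether a nitrile or a methoxy group at the same aromatic carbon would follow these steps remains open. So does the outcome with an amine or a carboxylic acid there.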